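A few compounds are considered here, and "the series" means these few. Any claim that something is new, unique, unknown or untested is made for them only; others in the source may bear on it.

In a functional assay on BXPC-3 cells (Homo sapiens) for inhibition, read by MTT assay, with a stated time of 7 days (on this read-out higher numbers stand for weaker inhibition and lower numbers for stronger inhibition), three compounds sharing one core have been measured: compound 1 `CCN(CC)S(=O)(=O)c1ccc(S(=O)(=O)N2CCC[C@@H](C(=O)N(C)C(C)C)C2)cc1` gives 7700 nM, compound 2 `CCN(CC)S(=O)(=O)c1ccc(S(=O)(=O)N2CCC[C@@H](C(=O)NC3CN(C(=O)C4CC4)C3)C2)cc1` gives 18500 nM, and compound 3 `CCN(CC)C(=O)[C@@H]1CCCN(S(=O)(=O)c2ccc(S(=O)(=O)N(CC)CC)cc2)C1` gives 10500 nM. Compound 3 lies within the scatter of both others, as shown by a 1.4-fold higher number from compound 1 to compound 3 (0.13 log units; within the scatter) and by a 1.8-fold lower number from compound 2 to compound 3 (0.25 log units; within the scatter). Compound 4 `CCN(CC)S(=O)(=O)c1ccc(S(=O)(=O)N2CCC[C@@H](C(=O)NC3COC3)C2)cc1` carries (oxetan-3-yl)amino in place of diethylamino on a carbonyl carbon. All three measured steps are changes on this same carbonyl carbon. The only one beyond the scatter is modest, a 2.4-fold higher number from compound 1 to compound 2 (0.38 log units; beyond the scatter). It leads to compound 2, whose group also holds a four-membered non-aromatic ring, and that compound is the nearest measured parallel to compound 4. Since the measured steps at this place are small, only a small move towards the value of compound 2 is expected, not one clearly beyond the scatter. The expected step is a 1.2-fold higher number from compound 3 to compound 4 (0.09 log units; within the scatter). For compound 4 the estimated value is 13000 nM, with an expected range from 6000 nM to 28000 nM.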

Compound 4, half-maximal inhibitory concentration: 13800 nM
For compound 4 the middle estimate is 1.1-fold (0.03 log units) below the measured one; the range from low to high includes it.
By their numbers in this assay, from the lowest: compounds 1, 3, 4 and 2 (each within the scatter of the next, the first and the last beyond it).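

In this assay, (oxetan-3-yl)amino on the carbonyl carbon brings a four-membered non-aromatic ring, a hydrogen-bond donor and a hydrogen-bond acceptor where diethylamino has none, yet the change stays within the scatter (a 1.3-fold higher number from compound 3 to compound 4 (0.12 log units; within the scatter)). For the compounds shown here, compound 4 also lies within the scatter of the two compounds whose values are furthest apart (a 1.3-fold lower number from compound 2 to compound 4 (0.13 log units; within the scatter); a 1.8-fold higher number from compound 1 to compound 4 (0.25 log units; within the scatter)), so the one step beyond the scatter, between compound 1 and compound 2, now has a compound that cannot be told apart from either end. No measurement shown here explains why this exchange leaves the number within the scatter.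

The compounds shown leave open whether a primary amine, a carboxylic acid or a longer alkyl chain on this carbonyl carbon would move the number beyond the scatter. They also leave open whether any group at this place can give a value clearly apart from all four.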